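The source may report more compounds than this note shows. Statements on the series, on what has been measured and on what is new or still open speak of the compounds shown alone.

Measured compounds:
compound 1 `Oc1cccc(-c2cc(-c3ccccc3C(F)(F)F)cc(-c3ccccc3O)n2)c1` — 16800 nM
compound 2 `Oc1cccc(-c2cc(-c3ccccc3C(F)(F)F)cc(-c3cccc(O)c3)n2)c1` — 15200 nM

In a functional assay on HeLa cells (Homo sapiens) for inhibition (a higher number here means a weaker inhibitor, a lower number a stronger inhibitor), compound 1 gives 16800 nM and compound 2 gives 15200 nM. For the measured compounds named here, compound 2 thus stands at one end of a pair of numbers that the scatter does not separate: the single measured step, a 1.1-fold lower number from compound 1 to compound 2 (0.04 log units; within the scatter), shows that moving the hydroxyl from the 2-position to the 3-position of this phenyl ring left the number essentially unchanged.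

Compound 3 `Oc1ccc(-c2cc(-c3ccccc3C(F)(F)F)cc(-c3cccc(O)c3)n2)cc1` arises from compound 2 by 4-hydroxyphenyl in place of 3-hydroxyphenyl on an aromatic carbon. This is the same kind of move as the measured step, a shift of the hydroxyl around the same ring, and that step stayed within the scatter. On that basis no change beyond the scatter is expected in this assay for compound 3, so the estimated step is a 1.0-fold lower number from compound 2 to compound 3 (0.01 log units; within the scatter). Compound 3 is therefore expected to give about 15000 nM, with a range from 7000 nM to 33000 nM.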

Compound 3, half-maximal inhibitory concentration: 17400 nM
Compound 3: the middle estimate sits 1.2-fold (0.06 log units) below what was measured, and the stated range covers the measured number.
By their numbers in this assay, from the lowest: compounds 2, 1 and 3 (each within the scatter of the next).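

With the hydroxyl at the 4-position, the series now covers all three placements on this phenyl ring, and none of them separates from the others in this assay. There is a 1.1-fold higher number from compound 2 to compound 3 (0.06 log units; within the scatter), and there is a 1.0-fold higher number from compound 1 to compound 3 (0.02 log units; within the scatter), so in these compounds the place of the hydroxyl on this ring, whether 2, 3 or 4, makes no difference that the scatter can resolve. No measurement is available that would explain this flat result.

The compounds shown leave open whether a different group on this ring, such as an amine, a carboxylic acid or a methoxy group, would move the number beyond the scatter. They also leave open how the number would respond to a change at the 2-(trifluoromethyl)phenyl group or at the 3-hydroxyphenyl group that all three compounds share.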